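From an open chain to a ring on the carbonyl

A few compounds are considered here, and "the series" means these few. Any claim that something is new, unique, unknown or untested is made for them only; others in the source may bear on it.

Compound 1 `CC(C)(C)C(=O)N1Cc2c(NC(=O)C3CCNCC3)n[nH]c2C1(C)C`: 650 nM
Compound 2 `CC(C)(C)C(=O)N1Cc2c(NC(=O)c3ccc(F)cc3)n[nH]c2C1(C)C`: 270 nM
Compound 3 `CN(C)CC(=O)Nc1n[nH]c2c1CN(C(=O)C(C)(C)C)C2(C)C`: 580 nM

In a functional assay on A2780 cells (Homo sapiens) for antiproliferative activity, read by fluorescence, with a stated time of 72 h (on this read-out higher numbers stand for weaker inhibition and lower numbers for stronger inhibition), compound 3 gives 580 nM. It sits in the upper part of this small set, level with its nearest neighbour within the scatter: a 1.1-fold lower number from compound 1 to compound 3 (0.05 log units; within the scatter). The gap on the other side is larger: a 2.1-fold higher number from compound 2 to compound 3 (0.33 log units; beyond the scatter).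

The next compound to be measured is compound 4 `CN1CCC(C(=O)Nc2n[nH]c3c2CN(C(=O)C(C)(C)C)C3(C)C)CC1`. It differs in one place, where 1-methylpiperidin-4-yl replaces (dimethylamino)methyl on a carbonyl carbon: 1-methylpiperidin-4-yl in place of (dimethylamino)methyl on a carbonyl carbon.

The most relevant evidence comes from compound 1, which carries piperidin-4-yl, a close relative of the entering group. Exchanging that ring for the same open chain made little difference: a 1.1-fold lower number from compound 1 to compound 3 (0.05 log units; within the scatter). The modest steps involving 4-fluorophenyl, a 2.4-fold lower number from compound 1 to compound 2 (0.38 log units; beyond the scatter) and a 2.1-fold higher number from compound 2 to compound 3 (0.33 log units; beyond the scatter), bear on this change less directly, since compound 4 does not carry that group. No measurement here isolates the extra methyl.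

No change beyond the scatter is therefore expected in this assay. The expected size of the step is a 1.1-fold lower number from compound 3 to compound 4 (0.02 log units; within the scatter). For compound 4 the estimated value is 550 nM, with an expected range of 250 nM to 1200 nM.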

Compound 4, half-maximal inhibitory concentration in the A2780 assay: 350 nM
Compound 4: middle estimate off by 1.6-fold (0.20 log units), on the high side; the range from low to high includes it.
By their numbers in the A2780 assay, from the lowest: compounds 2, 4, 3 and 1 (each within the scatter of the next, the first and the last beyond it).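

In the A2780 assay, the 1-methylpiperidin-4-yl group on the carbonyl carbon reads level with the open chain, a 1.7-fold lower number from compound 3 to compound 4 (0.22 log units; within the scatter), and also with the flat aromatic group, a 1.3-fold higher number from compound 2 to compound 4 (0.11 log units; within the scatter). Among the compounds shown here, the methyl in place of hydrogen on the ring nitrogen, which no earlier pair isolated, also stays within the scatter: a 1.9-fold lower number from compound 1 to compound 4 (0.27 log units; within the scatter). In a physicochemical assay for solubility, at pH 7 (on this read-out lower numbers stand for lower solubility and higher numbers for higher solubility), compound 3 gives > 225000 nM, which is a limit of the assay and not a number. In the physicochemical assay, compound 4 gives > 225000 nM, which is a limit of the assay and not a number, so the steps in that assay cannot be read and it cannot separate the ring from the open chain: the limit of > 225000 nM in the physicochemical assay, at which 2 of the 2 values shown sit.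

The compounds shown leave open whether a larger group on the ring nitrogen, such as an acetyl or a benzyl group, would move the number in the A2780 assay beyond the scatter, since a single pair speaks only for methyl. Going by these compounds, it is also open how a carboxylic acid or a longer amine chain on the carbonyl carbon would read in the A2780 assay, and whether any such group would bring a readable number in the physicochemical assay.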